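The source may report more compounds than this note shows. Statements on the series, on what has been measured and on what is new or still open speak of the compounds shown alone.

Working notes on the series. Compound 1 `CC(=O)N1CCC[C@H]1C(=O)OCC(F)F` and compound 3 `CC(=O)N1CCC[C@H]1C(=O)OCCF` share one core; compound 2 `FC(F)CCOc1ccc2[nH]ccc2c1` and compound 4 `FCCCOc1ccc2[nH]ccc2c1` share another, and the difference between the two cores is not broken down here. In a physicochemical assay for lipophilicity, read by NMR (a lower number here means a more polar compound, a higher number a more lipophilic compound), compound 1 gives 0.02 and compound 3 gives -0.43, which is a number 0.45 log units lower from compound 1 to compound 3 (beyond the scatter) for the change (hydrogen in place of fluoro on a saturated chain carbon bound to a fluorine atom and a saturated chain carbon). Compound 2 gives 2.6 in this assay, the highest of the three numbers. Compound 4 carries the same change on the core of compound 2, namely (hydrogen in place of fluoro on a saturated chain carbon bound to a fluorine atom and a saturated chain carbon). Among the measured compounds shown here, the step is expected to be a number 0.45 log units lower from compound 2 to compound 4 (beyond the scatter), beside the earlier one, because the only measured instance of this change is a number 0.45 log units lower from compound 1 to compound 3 (beyond the scatter). Compound 4 is therefore estimated at 2.15 in this assay, between 1.75 and 2.55.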

Compound 4, partition coefficient: 2.5
Compound 4: middle estimate off by 0.35 log units, on the low side, within the range that was stated.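

In this assay the same replacement of fluoro by hydrogen gives a number 0.10 log units lower from compound 2 to compound 4 (within the scatter) on one core and a number 0.45 log units lower from compound 1 to compound 3 (beyond the scatter) on the other, so the step printed for one core did not reappear at the same size on the other. These two pairs show that the step need not be the same on both cores, but they do not give a general rule for how it depends on the core. Nothing shown here accounts for the difference between the two steps.

Still open, from the compounds shown here alone, is how the same replacement reads on a 4,4-difluorobutyl chain or another longer chain. Also open, going by these compounds, is how it reads on a core carrying an amine or a carboxylic acid.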